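A few compounds are considered here, and "the series" means these few. Any claim that something is new, unique, unknown or untested is made for them only; others in the source may bear on it.

In a functional assay on P388 cells (Mus musculus) for antiproliferative activity, read by colorimetric assay and MTT assay (a lower number here means a stronger inhibitor, a higher number a weaker inhibitor), compound 1 `Nc1ccc(S(=O)(=O)Nc2cccc3c(Cl)c[nH]c23)cc1` gives 0.81 ug/mL. On the same core, compound 2 `Nc1ccc(S(=O)(=O)Nc2ccc(Br)c3c(Cl)c[nH]c23)cc1`, with bromo in place of hydrogen on an aromatic carbon, gives 0.64 ug/mL, and compound 3 `Cc1ccc(NS(=O)(=O)c2ccc(N)cc2)c2[nH]cc(Cl)c12`, with methyl in place of hydrogen on an aromatic carbon, gives 0.37 ug/mL. Compound 3 stands clear of compound 1 only, with a 2.2-fold lower number from compound 1 to compound 3 (0.34 log units; beyond the scatter). Against compound 2 the data show a 1.7-fold lower number from compound 2 to compound 3 (0.24 log units; within the scatter), and the bromo change itself gave a 1.3-fold lower number from compound 1 to compound 2 (0.10 log units; within the scatter).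

Compound 4 `COc1ccc(NS(=O)(=O)c2ccc(N)cc2)c2[nH]cc(Cl)c12` carries methoxy in place of methyl on an aromatic carbon, (methoxy in place of methyl on an aromatic carbon). Going by the values given here, no measured compound holds a methoxy group, so the only guides are the three single-group steps above. Those steps are small, the largest being a 2.2-fold lower number from compound 1 to compound 3 (0.34 log units; beyond the scatter), which is a modest change. On that basis no step beyond the scatter is expected in this assay, in either direction. The expected step is a 1.1-fold higher number from compound 3 to compound 4 (0.06 log units; within the scatter). Compound 4 is estimated at 0.42 ug/mL, with an expected range from 0.17 ug/mL to 1 ug/mL.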

Compound 4, half-maximal inhibitory concentration: 5.5 ug/mL
Compound 4: the middle estimate sits 13-fold (1.12 log units) below what was measured; measured number above the stated range.
By their numbers in this assay, from the lowest: compounds 3, 2 and 1 (each within the scatter of the next, the first and the last beyond it); then compound 4.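

In this assay, going by these compounds alone, hydrogen, bromo and methyl at this position had differed by modest steps at most, but methoxy in place of methyl gives the only large step in the set (a 15-fold higher number from compound 3 to compound 4 (1.17 log units; beyond the scatter)). The methoxy compound also separates from the bromo and hydrogen compounds (an 8.6-fold higher number from compound 2 to compound 4 (0.93 log units; beyond the scatter); a 6.8-fold higher number from compound 1 to compound 4 (0.83 log units; beyond the scatter)), so compound 4 is the weakest of the four, beyond the scatter of each of the others, and this position proves far less forgiving than the first three compounds suggested. Nothing available here explains why this one change, which brings in an oxygen and a hydrogen-bond acceptor, stands so far from the other three groups.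

The compounds shown leave open whether the loss belongs to methoxy alone or to any group joined through oxygen, a question that a hydroxyl or an ethoxy group at this position could address, with an ethyl group or an amine as further comparisons. They also leave open whether methoxy would give a step of this size elsewhere on the shared core.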